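The source may hold more compounds than are shown below. What is called first, only, known or untested is meant among the compounds shown, and "the series" means these compounds.

Measured so far:
compound 1 `CCCSc1nc(N/N=C/c2ccccc2F)c2nnn(Cc3ccccc3)c2n1` gives > 64000 nM in a functional assay on MCF7 cells (Homo sapiens) for antiproliferative activity, read by MTT assay, with a stated time of 72 h; on this read-out lower numbers stand for stronger inhibition and higher numbers for weaker inhibition.
compound 2 `CCCSc1nc(N/N=C(\C)c2ccccc2O)c2nnn(Cc3cccc(Cl)c3)c2n1` gives 39900 nM.

Compound 1 is known only by a limit: in this assay compound 1 gives > 64000 nM, which is a limit of the assay and not a number. Compound 2 gives a measured figure of 39900 nM, so both compounds sit at the weak end of what this assay can resolve. Compound 3 `CCCSc1nc(N/N=C(\C)c2ccc(Br)cc2)c2nnn(Cc3ccccc3)c2n1` has not yet been tested. It differs from compound 1 in one place: a group of 10 heavy atoms (8 carbon, 1 nitrogen, 1 bromine; one six-membered aromatic ring of carbon only) in place of a group of 9 heavy atoms (7 carbon, 1 nitrogen, 1 fluorine; one six-membered aromatic ring of carbon only), on a nitrogen on an aromatic ring. Going by the values given here, no measured pair shows what such a change does here, and compound 1 itself sits at the limit of > 64000 nM in this assay, at which 1 of the 2 values shown sits. The expected step from compound 1 to compound 3 is therefore small or none beyond the scatter: an at least 1.1-fold lower number from compound 1 to compound 3 (0.06 log units; that floor lies within the scatter). Compound 3 is estimated at 55000 nM, within a range from 20000 nM to 150000 nM, with a real chance that this assay again reports only a limit.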

Compound 3, half-maximal inhibitory concentration: 13000 nM
For compound 3 the middle estimate is 4.2-fold (0.63 log units) above the measured one; the measured number lies below the stated range.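

In this assay, putting the group of 10 heavy atoms with bromine in place of the group of 9 heavy atoms with fluorine, on a nitrogen on an aromatic ring, gives an at least 4.9-fold lower number from compound 1 to compound 3 (0.69 log units; beyond the scatter). This place is therefore not silent: one change here is enough to move a compound from a limit of the assay to a measured figure, which the two earlier compounds alone could not show. The step is only a floor, because one of its ends is a limit and not a number: the limit of > 64000 nM in this assay, at which 1 of the 3 values shown sits.

The two groups differ both in their halogen and in their count of carbon, so this single pair cannot tell which of the two carries the step. Going by these compounds, whether an amine or a carboxylic acid at this same place would lower the number further also stays open.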